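From compound 3 to its hydroxy counterpart, compound 4

This account rests on a few compounds, and the source may have more. Where it says the series, first, only, none or still open, it means among the compounds named here.

Measured in an ADME assay on cells (Hepatocyte, Homo sapiens) for metabolic stability, with a stated time of 30 min (on this read-out higher numbers stand for a more stable compound and lower numbers for a less stable compound), so far:
- compound 1 `NC1CCC(CN2CCN(c3cc(=O)c4cc(C(F)(F)F)cc([N+](=O)[O-])c4s3)CC2)CC1` gives 83.6%
- compound 2 `O=C(NC1CCC(CN2CCN(c3cc(=O)c4cc(C(F)(F)F)cc([N+](=O)[O-])c4s3)CC2)CC1)c1ccccc1` gives 92.9%
- compound 3 `O=C(OC1CCC(CN2CCN(c3cc(=O)c4cc(C(F)(F)F)cc([N+](=O)[O-])c4s3)CC2)CC1)C1CCCCC1` gives 2.8%

Compound 3 stands lowest of the three in this assay, with both other compounds beyond the scatter above it. Compound 4 `O=c1cc(N2CCN(CC3CCC(O)CC3)CC2)sc2c([N+](=O)[O-])cc(C(F)(F)F)cc12` differs from it by hydrogen in place of cyclohexylcarbonyl on an oxygen on a saturated carbon, so that (cyclohexylcarbonyl)oxy becomes hydroxy. Going by the values given here, two measured steps bear on this site, and both are large: a number 80.8 percentage points lower from compound 1 to compound 3 (beyond the scatter) and a number 90.1 percentage points lower from compound 2 to compound 3 (beyond the scatter) end at the same compound. By contrast, the benzoyl step gives a number 9.3 percentage points higher from compound 1 to compound 2 (within the scatter) and so separates the two higher compounds by no more than the scatter. Among the compounds with values here, no measured compound carries hydroxy, which leaves the read-across indirect. Only compound 3 holds the (cyclohexylcarbonyl)oxy group, and compound 4 gives it up, so a large upward step is expected, estimated as a number 77.2 percentage points higher from compound 3 to compound 4 (beyond the scatter) in this assay overall. Compound 4 is expected at 80% (estimated range 55% to 96%).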

Compound 4, percent of the compound remaining: 72.7%
Compound 4: the middle estimate sits 7.3 percentage points above what was measured; measured number inside the range.
By their numbers in this assay, from the lowest: compound 3; then compound 4; then compounds 1 and 2 (each within the scatter of the next).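

In this assay there is a number 69.9 percentage points higher from compound 3 to compound 4 (beyond the scatter) on loss of the cyclohexylcarbonyl, so an oxygen on this saturated ring carbon does not by itself carry the low number of compound 3; the low number goes with the complete (cyclohexylcarbonyl)oxy group. Hydroxy does not fully match the nitrogen-linked groups, with a number 10.9 percentage points lower from compound 1 to compound 4 (beyond the scatter) for the change from amino and a number 20.2 percentage points lower from compound 2 to compound 4 (beyond the scatter) for the change from benzamido, both modest. The data on hand offer no explanation for these differences.

As far as these compounds go, it remains open whether a smaller acyl group such as acetyl on the same oxygen gives a number near that of compound 3, and whether a cyclohexanecarboxamide at this carbon stays near compound 2. A methyl ether or a carboxylic acid at this carbon also remains to be placed against hydroxy.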